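The compounds below may be only part of what the source reports. "The series", "measured", "known", "first", "only" and "open" are said of these compounds alone.

Measured so far:

Compound 1, `Nc1nc(-c2ccccc2)nc2sc(-c3ccccc3)nc12`: 148 nM
Compound 2, `Nc1nc(-c2ccc(CO)cc2)nc2sc(-c3ccccc3)nc12`: 82 nM
Compound 3, `Nc1nc(-c2cccc(O)c2)nc2sc(-c3ccccc3)nc12`: 58.5 nM

In an assay on CHO cells for displacement of a labelled ligand from adenosine receptor A1 (Homo sapiens), read by scintillation counting, with a stated time of 3 h (on this read-out lower numbers stand for stronger inhibition and higher numbers for weaker inhibition), compound 3 holds the lowest of the three numbers. Its gap to compound 2 is small, a 1.4-fold lower number from compound 2 to compound 3 (0.15 log units; within the scatter), while the gap to compound 1 is larger, a 2.5-fold lower number from compound 1 to compound 3 (0.40 log units; beyond the scatter). Compound 4, `Nc1nc(-c2ccco2)nc2sc(-c3ccccc3)nc12`, differs from compound 3 in one place: furan-2-yl in place of 3-hydroxyphenyl on an aromatic carbon.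

Among the measured compounds shown here, two measured steps bear on this change. Adding a hydroxy group to compound 1 gave compound 3, a 2.5-fold lower number from compound 1 to compound 3 (0.40 log units; beyond the scatter), and adding a hydroxymethyl group gave compound 2, a 1.8-fold lower number from compound 1 to compound 2 (0.26 log units; within the scatter). For the measured compounds named here, compound 4 gives up the hydroxy group that set compound 3 apart from compound 1, and at the same time swaps the six-membered ring for a five-membered one, a swap no measured pair covers. The number for compound 4 is therefore expected to move back up toward that of compound 1, a step of about a 2.6-fold higher number from compound 3 to compound 4 (0.41 log units; beyond the scatter). Going by the values given here, the uncertainty is wide, since the only guide is compound 1 at 148 nM. Compound 4 is estimated at 150 nM, within 50 nM to 450 nM.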

Compound 4, inhibition constant: 67 nM
Compound 4: the middle estimate sits 2.2-fold (0.35 log units) above what was measured; the range from low to high includes it.
By their numbers in this assay, from the lowest: compounds 3, 4, 2 and 1 (each within the scatter of the next, the first and the last beyond it).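

In this assay, furan-2-yl at this position cannot be told apart from the two larger ring groups that carry oxygen: a 1.1-fold higher number from compound 3 to compound 4 (0.06 log units; within the scatter), and a 1.2-fold lower number from compound 2 to compound 4 (0.09 log units; within the scatter). Against the plain phenyl group the picture differs, with a 2.2-fold lower number from compound 1 to compound 4 (0.34 log units; beyond the scatter), so a five-membered ring with no hydrogen-bond donor reaches the same range as the 3-hydroxyphenyl group, and a hydroxy group is not required for a number in that range. The data shown offer no explanation for this result.

From the compounds shown here alone, it remains open whether the furan oxygen matters, which a thiophene ring or a pyrrole ring at this position could help to show. Going by these compounds, it is also open how a phenyl ring bearing an amine or a carboxylic acid would compare.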